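Carrying the Benzylic Swap onto the Tetrazole Core

The source may report more compounds than this note shows. Statements on the series, on what has been measured and on what is new or still open speak of the compounds shown alone.

Compound 1 `Cc1cccc(Cc2nc3cc(O[C@H]4CC[C@@H](C(=O)O)CC4)ccc3n2C)c1` gives 42 nM in an assay on isolated protein for inhibition of Long-chain-fatty-acid--CoA ligase 1 (Homo sapiens), read by mass spectrometry, with a stated time of 90 min, in the presence of a further agent that is not named here; a higher number here means a weaker inhibitor, a lower number a stronger inhibitor. Compound 2 `Cn1c(Cc2ccc3c(c2)OCC3)nc2cc(O[C@H]3CC[C@@H](C(=O)O)CC3)ccc21` differs from it by a group of 9 heavy atoms (8 carbon, 1 oxygen; one five-membered non-aromatic ring with 1 hetero atom, one six-membered aromatic ring of carbon only) in place of a group of 7 heavy atoms (7 carbon; one six-membered aromatic ring of carbon only), on a saturated chain carbon bound to an aromatic carbon and gives 13 nM in this assay, a step of a 3.2-fold lower number from compound 1 to compound 2 (0.51 log units; beyond the scatter). Compound 3 `Cc1cccc(Cc2nc3cc(O[C@H]4CC[C@@](F)(c5nnn[nH]5)CC4)ccc3n2C)c1` carries a different core; the difference between its core and the core of compound 1 is not broken down here. In this assay compound 3 gives 13 nM, level with compound 2 at the digits given. Compound 4 `Cn1c(Cc2ccc3c(c2)OCC3)nc2cc(O[C@H]3CC[C@@](F)(c4nnn[nH]4)CC3)ccc21` applies the same change to compound 3: a group of 9 heavy atoms (8 carbon, 1 oxygen; one five-membered non-aromatic ring with 1 hetero atom, one six-membered aromatic ring of carbon only) in place of a group of 7 heavy atoms (7 carbon; one six-membered aromatic ring of carbon only), on a saturated chain carbon bound to an aromatic carbon. Because compound 2 improved on compound 1 by a 3.2-fold lower number from compound 1 to compound 2 (0.51 log units; beyond the scatter), a similar step is expected for compound 4, a 2.6-fold lower number from compound 3 to compound 4 (0.41 log units; beyond the scatter), allowing that a second instance may fall short of the first. Compound 4 is therefore estimated at 5 nM, with a likely range from 2 nM to 15 nM.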

Compound 4, half-maximal inhibitory concentration: 3 nM
Compound 4: middle estimate off by 1.7-fold (0.22 log units), on the high side, within the range that was stated.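

In this assay, replacing 3-methylphenyl with the group containing the five-membered non-aromatic ring also lowered the number on the second core, with a 4.3-fold lower number from compound 3 to compound 4 (0.64 log units; beyond the scatter). The change gave steps of matching size on the two cores: the same change on two cores in this assay, a 3.2-fold lower number (0.51 log units; beyond the scatter) from compound 1 to compound 2 and a 4.3-fold lower number (0.64 log units; beyond the scatter) from compound 3 to compound 4, 1.3-fold (0.13 log units) apart, within the scatter of two such steps

This agreement rests on a single pair of cores in one assay, so it does not show that the change would carry over to other cores, nor does it explain why the number falls. The compounds shown leave open how much of the step depends on the ring oxygen. From the compounds shown here alone, it also remains open how an amine or a longer chain would compare when placed on the same saturated chain carbon.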